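Cytotoxicity notes: from propoxymethyl amide to 4-bromophenyl amide

The compounds below may be only part of what the source reports. "The series", "measured", "known", "first", "only" and "open" are said of these compounds alone.

Three amides of a shared core have been read in an ADME assay on Vero cells (Chlorocebus sabaeus) for cytotoxicity, read by resazurin assay, with a stated time of 3 days; on this read-out lower numbers stand for stronger inhibition and higher numbers for weaker inhibition. Compound 1 `CN(C)c1cc2[nH]c(C3CCCCC3)nc2cc1NC(=O)c1cccs1` carries thiophen-2-yl on the carbonyl carbon; in this assay compound 1 gives > 100 ug/mL, which is a limit of the assay and not a number. Compound 2 `Cc1ccc(C(=O)Nc2cc3nc(C4CCCCC4)[nH]c3cc2N(C)C)cc1` carries 4-methylphenyl on that carbon; compound 2 gives > 100 ug/mL, again only a limit. Compound 3 `CCCOCC(=O)Nc1cc2nc(C3CCCCC3)[nH]c2cc1N(C)C` carries propoxymethyl; compound 3 gives < 50 ug/mL, also a limit. Compound 3 thus stands at the limit of < 50 ug/mL in this assay, at which 1 of the 3 values shown sits, while the two aryl amides sit at the limit of > 100 ug/mL in this assay, at which 2 of the 3 values shown sit. The measured steps read an at least 2.0-fold lower number from compound 1 to compound 3 (0.30 log units; that floor lies within the scatter) and an at least 2.0-fold lower number from compound 2 to compound 3 (0.30 log units; that floor lies within the scatter); the remaining step is a step that the two limits leave unreadable from compound 1 to compound 2.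

Compound 4 `CN(C)c1cc2[nH]c(C3CCCCC3)nc2cc1NC(=O)c1ccc(Br)cc1` is the next member: 4-bromophenyl in place of propoxymethyl on a carbonyl carbon. This change runs back toward the aryl amides, compound 2 in particular, so the step of an at least 2.0-fold lower number from compound 2 to compound 3 (0.30 log units; that floor lies within the scatter) is the one that bears on it, read in reverse. Compound 4 is therefore expected to give a higher number, an at least 3.0-fold higher number from compound 3 to compound 4 (0.47 log units; beyond the scatter). The estimate for compound 4 is 150 ug/mL, with a range from 50 ug/mL to 400 ug/mL, and a limit rather than a number is the more likely read-out.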

Compound 4, half-maximal inhibitory concentration: > 100 ug/mL
Compound 4: no number, only a limit (the forecaster's own chance of this, stated with the estimate: 70%); the middle value does not contradict the limit.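

At this carbonyl carbon, a third ring-bearing amide now separates from the propoxymethyl amide in this assay, with an at least 2.0-fold higher number from compound 3 to compound 4 (0.30 log units; that floor lies within the scatter). Compound 4 sits at the same limit as compound 1 and compound 2, so all three ring-bearing amides shown share one read-out, and compound 3 alone differs: the limit of > 100 ug/mL in this assay, at which 3 of the 4 values shown sit. The steps from compound 1 and from compound 2 to compound 4 cannot be read, so exchanging bromo for methyl on an aromatic carbon shows no measurable effect here, and no order among the three can be drawn.

Going by these compounds, both ends of the gap are limits, so its true size stays open. On these data alone, it also stays open whether a plain butyl chain or an aminomethyl group on the carbonyl carbon would read with compound 3 or with the ring-bearing amides.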